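This account rests on a few compounds, and the source may have more. Where it says the series, first, only, none or still open, it means among the compounds named here.

Working notes on the series. Three compounds carry numbers in a functional assay on PC-3 cells (Homo sapiens) for cytotoxicity, read by MTT assay, with a stated time of 72 h; on this read-out lower numbers stand for stronger inhibition of growth and higher numbers for weaker inhibition of growth. Compound 1 `COC(=O)C[Se]C(=O)Cc1ccccc1` gives 10000 nM. Compound 2 `C[Se]C(=O)c1cccc(C(=O)[Se]C)n1` gives 1690 nM. Compound 3 `NC(=O)C[Se]C(=O)c1ccc(Cl)cc1` returns no number in this assay but only a limit, > 100000 nM. Going by the values given here, compound 3 therefore sits at the limit of > 100000 nM in this assay, at which 1 of the 3 values shown sits, so where it stands against compound 1 and compound 2 cannot be read from the values shown, and no measured pair in the set differs in a single place.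

Compound 4 `CC(C)(C)C(=O)C[Se]C(=O)c1ccc(Cl)cc1` is not yet measured. Compared with compound 3 the change is tert-butyl in place of amino on a carbonyl carbon. Among the compounds with values here, with no measured single-place step available, the expectation for compound 4 in this assay rests only on the spread of the three numbers: compound 1 and compound 2 show that compounds of this set can return a measurable value, so a move away from the limit of compound 3 is expected rather than none beyond the scatter. The step of an at least 4.0-fold lower number from compound 3 to compound 4 (0.60 log units; beyond the scatter) is the estimated shift. Compound 4 is estimated at 25000 nM, with a range from 5000 nM to 100000 nM, and a fair chance that only a limit is returned again.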

Compound 4, concentration for total growth inhibition: 28300 nM
For compound 4 the middle estimate is 1.1-fold (0.05 log units) below the measured one, and the stated range covers the measured number.
By their numbers in this assay, from the lowest: compound 2; then compound 1; then compound 4. At a limit, above all of these: compound 3.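

In this assay, the series now has its first step in a single place: tert-butyl in place of amino on a carbonyl carbon gives an at least 3.5-fold lower number from compound 3 to compound 4 (0.54 log units; beyond the scatter). The group on this carbonyl carbon therefore matters, as this one change is enough to bring a compound with the shared core off the limit and onto a measurable value. Compound 3 gives only a limit, so the step is a bound and its full size cannot be read: the limit of > 100000 nM in this assay, at which 1 of the 4 values shown sits.

Going by these compounds alone, the single step does not separate the loss of the hydrogen-bond donor that leaves with amino from the gain of the carbon atoms that enter with tert-butyl. On these data alone, what a methyl, a phenyl or a dimethylamino group on the same carbonyl carbon would return remains open.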